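Adding a Phenoxy Group to a Weak Brain Inhibitor

This account rests on a few compounds, and the source may have more. Where it says the series, first, only, none or still open, it means among the compounds named here.

Compound 1 `Cc1[nH]c(=O)n(C)c1-c1ccccc1` was tested in a functional assay on brain (Rattus norvegicus, strain Wistar) for inhibition; a lower number here means a stronger inhibitor, a higher number a weaker inhibitor. Compound 1 gives only > 100000 nM, which is a limit of the assay rather than a measured number, as the limit of > 100000 nM in this assay, at which 1 of the 2 values shown sits, shows. Compound 2 `CCCCc1ccc(-c2c(CC)[nH]c(=O)n2C)cc1` gives 13900 nM in this assay. Compound 3 `Cc1[nH]c(=O)n(C)c1-c1ccc(Oc2ccccc2)cc1` is compound 1 with phenoxy in place of hydrogen on an aromatic carbon. Among the compounds with values here, no measured step between two compounds differing in one place is available, so the size of this change can only be estimated. Since compound 2 reaches 13900 nM with a larger group on the same ring, compound 3 is expected to be a stronger inhibitor than compound 1. The expected step is an at least 6.6-fold lower number from compound 1 to compound 3 (0.82 log units; beyond the scatter). Compound 3 is estimated at 15000 nM, ranging from 3000 nM to 80000 nM.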

Compound 3, half-maximal inhibitory concentration: 8100 nM
Estimate against measurement, compound 3: 1.9-fold (0.27 log units) above; the measured number falls inside the stated range.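

In this assay, within the data shown here, phenoxy in place of hydrogen on this aromatic carbon gives an at least 12-fold lower number from compound 1 to compound 3 (1.09 log units; beyond the scatter), the first step on the shared core that can be read from a change in one place. It shows that this carbon can carry a group as large as phenoxy with a clear gain in inhibition. The value for compound 1 is a limit and not a number: the limit of > 100000 nM in this assay, at which 1 of the 3 values shown sits.

Going by these compounds, it remains open whether a smaller group at this carbon, such as methoxy or an amine, would give a similar step. On these data alone, whether the oxygen or the added ring of phenoxy matters more also remains unknown.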